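Nitro to (4-chlorophenyl)carbamoyl in the series

This account rests on a few compounds, and the source may have more. Where it says the series, first, only, none or still open, it means among the compounds named here.

In a functional assay on NCI-H1975 cells (Homo sapiens) for cytotoxicity, read by MTT assay, with a stated time of 72 h (on this read-out lower numbers stand for stronger inhibition and higher numbers for weaker inhibition), compound 1 `CN1CCN(c2ccc(Nc3ncc4nc(Nc5cccc([N+](=O)[O-])c5)n(C5CCCC5)c4n3)cc2)CC1` gives 980 nM and sits at the low end of the series, together with compound 3 `CN1CCN(c2ccc(Nc3ncc4nc(Nc5ccc(Br)cc5F)n(C5CCCC5)c4n3)cc2)CC1` at 1120 nM within the scatter of it, while compound 2 `CN1CCN(c2ccc(Nc3ncc4nc(Nc5ccc(Br)cc5)n(C5CCCC5)c4n3)cc2)CC1` gives 2090 nM and lies beyond the scatter from compound 1. Compound 4 `CN1CCN(c2ccc(Nc3ncc4nc(Nc5cccc(C(=O)Nc6ccc(Cl)cc6)c5)n(C5CCCC5)c4n3)cc2)CC1` differs from compound 1 by (4-chlorophenyl)carbamoyl in place of nitro on an aromatic carbon with (4-chlorophenyl)carbamoyl in place of nitro on an aromatic carbon. For the measured compounds named here, three measured steps bear on this part of the molecule: a 2.1-fold higher number from compound 1 to compound 2 (0.33 log units; beyond the scatter) is modest, while a 1.1-fold higher number from compound 1 to compound 3 (0.06 log units; within the scatter) and a 1.9-fold lower number from compound 2 to compound 3 (0.27 log units; within the scatter) are smaller. None of them tests so large a group, so only a modest rise is expected in this assay and the direction stays uncertain. The expected change is a 1.5-fold higher number from compound 1 to compound 4 (0.18 log units; within the scatter) as an estimate. Compound 4 is estimated at 1500 nM with an expected range from 400 nM to 5000 nM for now.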

Compound 4, half-maximal inhibitory concentration: 4010 nM
The estimate for compound 4 lay 2.7-fold (0.43 log units) below the measured number; the range from low to high includes it.
By their numbers in this assay, from the lowest: compounds 1, 3, 2 and 4 (each within the scatter of the next, the first and the last beyond it).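

In this assay, for the compounds shown here, (4-chlorophenyl)carbamoyl in place of nitro gives a 4.1-fold higher number from compound 1 to compound 4 (0.61 log units; beyond the scatter) and is the first change at this position to bring in a second six-membered aromatic ring and an amide hydrogen. A group of this size on the aromatic carbon still leaves a measurable number rather than abolishing the read-out. No available measurement explains the rise.

Whether the amide link or the terminal 4-chlorophenyl accounts for the step stays open. So does whether a smaller group here, such as an amine or a carboxylic acid, would stay closer to compound 1.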